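Trimethylpyrazinylmethyl Ether Change Repeated on a Second Core

A few compounds are considered here, and "the series" means these few. Any claim that something is new, unique, unknown or untested is made for them only; others in the source may bear on it.

Measured in a functional assay on SH-SY5Y cells (Homo sapiens) for cytotoxicity, read by MTT assay, with stated times of 24 h and 4 h; on this read-out higher numbers stand for an effect only at larger amounts of compound and lower numbers for an effect already at smaller amounts:
compound 1 `COc1ccc(/C=C/C(=O)NCc2ccc(OCc3nc(C)c(C)nc3C)c(OC)c2)cc1O` gives 8560 nM;
compound 2 `COc1cc(CNC(=O)/C=C/c2ccc(OC)c(OCc3nc(C)c(C)nc3C)c2)ccc1OCc1nc(C)c(C)nc1C` gives 11600 nM;
compound 3 `COc1cccc(/C=C/C(=O)NCc2ccc(O)c(OC)c2)c1` gives 5240 nM.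

Compound 2 arises from compound 1 by one change, ((3,5,6-trimethylpyrazin-2-yl)methyl in place of hydrogen on an oxygen on an aromatic ring), and in this assay this made a 1.4-fold higher number from compound 1 to compound 2 (0.13 log units; within the scatter). Compound 3 sits lowest of the three values, though the gap to compound 1 lies within the scatter and only the gap to compound 2 is beyond it. The difference between the core of compound 3 and that of compound 1 is not broken down here.

Compound 4 `COc1cccc(/C=C/C(=O)NCc2ccc(OCc3nc(C)c(C)nc3C)c(OC)c2)c1` is not yet measured. It arises from compound 3 by (3,5,6-trimethylpyrazin-2-yl)methyl in place of hydrogen on an oxygen on an aromatic ring, the same change as from compound 1 to compound 2, occurring twice among the compounds shown. The surroundings of the place are described in identical words in both cases. Because a 1.4-fold higher number from compound 1 to compound 2 (0.13 log units; within the scatter) was within the scatter, compound 4 is expected to stand close to compound 3, with an estimated 1.3-fold higher number from compound 3 to compound 4 (0.13 log units; within the scatter). The estimate for compound 4 in this assay is 7000 nM, with a range from 3500 nM to 14000 nM, resting on a single earlier instance only.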

Compound 4, half-maximal effective concentration: 4320 nM
Estimate against measurement, compound 4: 1.6-fold (0.21 log units) above, and the stated range covers the measured number.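

In this assay, (3,5,6-trimethylpyrazin-2-yl)methyl in place of hydrogen on an oxygen on an aromatic ring gave a 1.2-fold lower number from compound 3 to compound 4 (0.08 log units; within the scatter), and the two instances of this change do not differ beyond what repeated measurements allow: the same change on two cores in this assay, a 1.4-fold higher number (0.13 log units; within the scatter) from compound 1 to compound 2 and a 1.2-fold lower number (0.08 log units; within the scatter) from compound 3 to compound 4, 1.6-fold (0.22 log units) apart, within the scatter of two such steps. The change thus carried from one core to the other with no step beyond the scatter on either, and exchanging the 3-hydroxy-4-methoxyphenyl for 3-methoxyphenyl likewise gave a 2.0-fold lower number from compound 1 to compound 4 (0.30 log units; within the scatter). This shows only that no effect of the change can be told apart from the scatter on these two cores in this one assay; with just two instances, it does not show that the change is without effect, or that it would behave the same way on a third core.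

The compounds shown leave open whether a different group on that oxygen, such as a chain ending in an amine or a carboxylic acid, would give a step beyond the scatter. They also leave open whether the change behaves alike on any other read-out.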